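Replacing 4-fluorophenyl with 3-methoxyphenyl on a shared core

The source may report more compounds than this note shows. Statements on the series, on what has been measured and on what is new or still open speak of the compounds shown alone.

Of the compounds shown here, three with a shared core have been measured in a functional assay on the whole organism (strain Kunming) with Mus musculus as the target, with a stated time of 0.5 h; a lower number here means that less compound is needed, a higher number that more compound is needed for the effect. Compound 1 (`COc1cc(OC)c(OC)cc1/C=C/COC(=O)/C=C/c1ccc(OC)c(OC)c1`) gives 140 umol/kg, compound 2 (`COc1cc(OC)c(OC)cc1/C=C/COC(=O)/C=C/c1ccccc1Cl`) gives 151 umol/kg, and compound 3 (`COc1cc(OC)c(OC)cc1/C=C/COC(=O)/C=C/c1ccc(F)cc1`) gives 92.9 umol/kg. Compound 3 therefore stands within the scatter of both others, as the measured steps show: a 1.5-fold lower number from compound 1 to compound 3 (0.18 log units; within the scatter), and a 1.6-fold lower number from compound 2 to compound 3 (0.21 log units; within the scatter).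

Compound 4 (`COc1cccc(/C=C/C(=O)OC/C=C/c2cc(OC)c(OC)cc2OC)c1`) carries 3-methoxyphenyl in place of 4-fluorophenyl on a double-bonded chain carbon bound to a double-bonded chain carbon.

All three measured steps involve exchanges at this same place. Besides the two above, there is a 1.1-fold higher number from compound 1 to compound 2 (0.03 log units; within the scatter), and none of the three goes beyond the scatter. Within the data shown here, no measured compound carries 3-methoxyphenyl itself. The nearest comparison is compound 1, whose 3,4-dimethoxyphenyl also bears methoxy groups, at 140 umol/kg. A small move from compound 3 toward that value therefore seems reasonable, and no step beyond the scatter is expected in this assay. The expected step is a 1.3-fold higher number from compound 3 to compound 4 (0.13 log units; within the scatter). For compound 4 the estimated value is 125 umol/kg, with an expected range from 70 umol/kg to 220 umol/kg.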

Compound 4, dose for half-maximal effect: 190 umol/kg
The estimate for compound 4 lay 1.5-fold (0.18 log units) below the measured number, and the stated range covers the measured number.
By their numbers in this assay, from the lowest: compounds 3, 1, 2 and 4 (each within the scatter of the next, the first and the last beyond it).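

In this assay, among these compounds, 3-methoxyphenyl in place of 4-fluorophenyl on a double-bonded chain carbon bound to a double-bonded chain carbon gives the first step at this place that passes the scatter, though only modestly (a 2.0-fold higher number from compound 3 to compound 4 (0.31 log units; beyond the scatter)). Among the compounds shown here, the other two steps to compound 4 stay within the scatter: one is the exchange of 3-methoxyphenyl for 2-chlorophenyl (a 1.3-fold higher number from compound 2 to compound 4 (0.10 log units; within the scatter)), and the other is hydrogen in place of methoxy on an aromatic carbon (a 1.4-fold higher number from compound 1 to compound 4 (0.13 log units; within the scatter)), so the methoxyphenyl, dimethoxyphenyl and chlorophenyl members of this set cannot be told apart, and only the pair of compound 3 and compound 4 separates. No measurement of any property of these groups bears on this result, and the gap between the fluorophenyl and the methoxyphenyl therefore stands without an explanation.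

The compounds shown cannot tell whether the gap follows from losing the fluorine or from gaining the methoxy, since a phenyl ring without any substituent does not appear among them. They also leave open what a dimethylamino group, a carboxylic acid or a nitrile on this ring would do, and whether an amide in place of the ester would keep the same narrow spread of values.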